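Aryl substitution on the amide-type nitrogen: compound 4

A few compounds are considered here, and "the series" means these few. Any claim that something is new, unique, unknown or untested is made for them only; others in the source may bear on it.

Compound 1 `CC1(C)C=C(n2ccccc2=O)c2cc(OC(=O)Nc3ccccc3)ccc2O1` is the unsubstituted phenyl member of the set; in a functional assay (trachea) with Rattus norvegicus as the target (a higher number here means a more potent compound, by a factor of ten per unit of this negative logarithm, a lower number a less potent compound), compound 1 gives 4.89. Compound 2 `CC1(C)C=C(n2ccccc2=O)c2cc(OC(=O)Nc3ccccc3F)ccc2O1` is the 2-fluorophenyl analogue, and in this assay compound 2 gives 4.22. Compound 3 `CC1(C)C=C(n2ccccc2=O)c2cc(OC(=O)Nc3ccc(F)cc3)ccc2O1` is the 4-fluorophenyl analogue, and in this assay compound 3 gives 4.37. Among the three values compound 3 stands second highest: compound 2 is nearest, within the scatter, and compound 1 is furthest, beyond the scatter.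

The measured steps that bear on the aryl group are a number 0.67 log units lower from compound 1 to compound 2 (beyond the scatter) and a number 0.52 log units lower from compound 1 to compound 3 (beyond the scatter), both modest losses for fluoro in place of hydrogen on an aromatic carbon, while a number 0.15 log units higher from compound 2 to compound 3 (within the scatter) lies within the scatter, so the two fluorophenyls are not separated.

Compound 4 `CC1(C)C=C(n2ccccc2=O)c2cc(OC(=O)Nc3ccccc3C(F)(F)F)ccc2O1` differs from compound 3 in one place: 2-(trifluoromethyl)phenyl in place of 4-fluorophenyl on an amide-type nitrogen. Within the data shown here, no measured step involves a trifluoromethyl, so the direction rests only on the observation that every substituted phenyl so far sits below compound 1 and the two substituted phenyls sit close together. A substituted phenyl is retained, so the expected step is small, a number 0.17 log units lower from compound 3 to compound 4 (within the scatter), leaning slightly lower. Compound 4 is therefore expected to give about 4.2, with a range from 3.7 to 4.7.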

Compound 4, logarithm of the reciprocal of the active concentration, log(1/C): 5.19
Compound 4: middle estimate off by 0.99 log units, on the low side; the whole stated range lies below it.
By their numbers in this assay, from the lowest: compounds 2 and 3 (each within the scatter of the next); then compounds 1 and 4 (each within the scatter of the next).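

The fluoro result does not extend to every group on this phenyl ring: with trifluoromethyl in place of fluoro on the same aromatic carbon, the step is a number 0.97 log units higher from compound 2 to compound 4 (beyond the scatter) in this assay, so the loss seen with 2-fluorophenyl depends on the group and does not follow from substitution alone. Compound 4 therefore goes against the earlier pattern of substituted phenyls sitting below the unsubstituted member, as a number 0.30 log units higher from compound 1 to compound 4 (within the scatter) leaves it not separated from compound 1, while the change from 4-fluorophenyl to 2-(trifluoromethyl)phenyl gives a number 0.82 log units higher from compound 3 to compound 4 (beyond the scatter) and alters both the group and its place on the ring in a single step. No measurement on hand accounts for the difference between fluoro and trifluoromethyl on this ring.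

With only these four aryl groups, the separate contributions of group and ring place cannot be assigned, and 4-(trifluoromethyl)phenyl would be the direct partner for compound 4 in settling that. As far as these compounds go, whether 2-methylphenyl, 2-chlorophenyl or 2-methoxyphenyl would track compound 2 or compound 4 remains open, as does the reading of any group larger than trifluoromethyl on this ring.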